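The compounds below may be only part of what the source reports. "The series", "measured", "known", "first", "only" and "open" are said of these compounds alone.

Four ureas sharing a common core were examined in an assay on isolated protein for inhibition of Polyunsaturated fatty acid 5-lipoxygenase (Homo sapiens), read by HPLC, with a stated time of 10 min; a higher number here means a weaker inhibitor, a lower number a stronger inhibitor. Compound 1, with the structure `Cc1cc(OCc2nc3ccccc3s2)ccc1NC(=O)Nc1ccc(Cl)c(Cl)c1`, gives 230 nM in this assay. Compound 2, `Cc1cc(OCc2nc3ccccc3s2)ccc1NC(=O)Nc1ccccc1Cl`, differs from compound 1 by 2-chlorophenyl in place of 3,4-dichlorophenyl on an amide-type nitrogen. In this assay compound 2 gives 830 nM; the step of a 3.6-fold higher number from compound 1 to compound 2 (0.56 log units; beyond the scatter). Compound 3, `O=C(Nc1ccc(OCc2nc3ccccc3s2)cc1)Nc1ccc(Cl)c(Cl)c1`, differs from compound 1 by hydrogen in place of methyl on an aromatic carbon. In this assay compound 3 gives 570 nM; the step of a 2.5-fold higher number from compound 1 to compound 3 (0.39 log units; beyond the scatter). The values of compound 2 and compound 3 lie within the usual scatter of each other, so no order between them is claimed.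

Compound 4, `O=C(Nc1ccc(OCc2nc3ccccc3s2)cc1)Nc1ccccc1Cl`, has not yet been measured in this assay. It differs from compound 3 by 2-chlorophenyl in place of 3,4-dichlorophenyl on an amide-type nitrogen. This is the same change as that from compound 1 to compound 2, made on the core of compound 3 instead of the core of compound 1, and the surroundings of the place where it is made read the same in both cases. Within the data shown here, the difference between the two cores is the one described from compound 1 to compound 3.

On the basis of the earlier step of a 3.6-fold higher number from compound 1 to compound 2 (0.56 log units; beyond the scatter), a step of similar size is expected in this assay from compound 3 to compound 4, namely a 3.3-fold higher number from compound 3 to compound 4 (0.52 log units; beyond the scatter). Among the measured compounds shown here, with only one prior example of this change, the range is kept wide. Compound 4 is therefore estimated to give about 1900 nM in this assay, with a likely span from 700 nM to 5000 nM.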

Compound 4, half-maximal inhibitory concentration: 360 nM
For compound 4 the middle estimate is 5.3-fold (0.72 log units) above the measured one; the measured number lies below the stated range.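

In this assay, 2-chlorophenyl in place of 3,4-dichlorophenyl on an amide-type nitrogen gives a 1.6-fold lower number from compound 3 to compound 4 (0.20 log units; within the scatter), so the change did not carry over unaltered from one core to the other: the same change on two cores in this assay, a 3.6-fold higher number (0.56 log units; beyond the scatter) from compound 1 to compound 2 and a 1.6-fold lower number (0.20 log units; within the scatter) from compound 3 to compound 4, 5.7-fold (0.76 log units) apart, beyond the scatter of two such steps. Read the other way, hydrogen in place of methyl on an aromatic carbon gives a 2.3-fold lower number from compound 2 to compound 4 (0.36 log units; beyond the scatter), and this step also differs from the one seen with 3,4-dichlorophenyl on the same nitrogen: the same change on two cores in this assay, a 2.5-fold higher number (0.39 log units; beyond the scatter) from compound 1 to compound 3 and a 2.3-fold lower number (0.36 log units; beyond the scatter) from compound 2 to compound 4, 5.7-fold (0.76 log units) apart, beyond the scatter of two such steps. These two comparisons rest on the same four compounds and form a single observation, which shows that in this set the size of each step depends on the group present at the other place, but it does not show why this happens or whether it extends beyond these compounds.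

The compounds shown cover only two groups on the amide-type nitrogen and two on the aromatic carbon, so it remains open whether the same interplay would appear with an unsubstituted phenyl, a methoxyphenyl or a trifluoromethylphenyl on that nitrogen. On these data alone, it also remains open whether an ethyl group or a methoxy group in place of the methyl would give steps closer to those of the core of compound 1 or of compound 3.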